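The source may report more compounds than this note shows. Statements on the series, on what has been measured and on what is new or still open speak of the compounds shown alone.

Measured in a functional assay on MCF7 cells (Homo sapiens) for antiproliferative activity, read by MTT assay, with a stated time of 72 h; a higher number here means a weaker inhibitor, a lower number a stronger inhibitor:
- compound 1, `COc1cc(-n2ncnc2-c2cccc([N+](=O)[O-])c2)cc(OC)c1OC`: > 10000 nM, a limit of the assay
- compound 2, `COc1cc(-c2ncnn2-c2ccc(Cl)cc2Cl)cc(OC)c1OC`: > 10000 nM, a limit of the assay
- compound 3, `COc1cc(-c2ncnn2-c2cccc([N+](=O)[O-])c2)cc(OC)c1OC`: > 10000 nM, a limit of the assay

Compound 1 thus stands nowhere distinct: the limit of > 10000 nM in this assay, at which 3 of the 3 values shown sit, so no order among the three can be drawn. Compound 4, `COc1cc(-n2ncnc2-c2cccc(Cl)c2)cc(OC)c1OC`, remains to be measured. It differs from compound 1 in one place, (chloro in place of nitro on an aromatic carbon). For the measured compounds named here, no measured pair differing in a single place exists, so the size of this step cannot be read off the series. Compound 2 already carries chloro on its own core and also sits at the limit, which gives no hint that chloro brings potency here. The step is therefore expected to be a step that the limit leaves unreadable from compound 1 to compound 4, none beyond the scatter, with compound 4 most likely reported again only as a limit. The estimated value for compound 4 is 20000 nM, range 8000 nM to 60000 nM.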

Compound 4, half-maximal inhibitory concentration: > 10000 nM
Compound 4 was reported as a limit; the forecaster's own chance of this, stated with the estimate: 85%; the middle value is on the limit's open side.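

Compound 1 and compound 4 both stand only as limits, so chloro in place of nitro gives no readable step: the limit of > 10000 nM in this assay, at which 4 of the 4 values shown sit. From the compounds shown here alone, whether the two groups differ at all on the shared core stays open.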